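The source may report more compounds than this note shows. Statements on the series, on what has been measured and on what is new or still open speak of the compounds shown alone.

Measured in an assay on isolated protein (artery, Oryctolagus cuniculus) with Substance-P receptor (Homo sapiens) as the target; a lower number here means tighter binding, a higher number weaker binding:
compound 1 `O=C1CCC(CCN2CC(N3CCC(O)C3)C2)(c2ccc(Cl)c(Cl)c2)CN1Cc1ccccc1` gives 2 nM
compound 2 `O=C1CCC(CCN2CC(N3CCNCC3)C2)(c2ccc(Cl)c(Cl)c2)CN1CC1CC1` gives 12.6 nM
compound 3 `NC(=O)N1CCN(C2CN(CCC3(c4ccc(Cl)c(Cl)c4)CCC(=O)N(CC4CC4)C3)C2)CC1` gives 5.01 nM

Compound 2 stands highest of the three numbers; compound 3 is nearest and compound 1 furthest, both beyond the scatter. Compound 4 `O=C1CCN(C2CN(CCC3(c4ccc(Cl)c(Cl)c4)CCC(=O)N(CC4CC4)C3)C2)CC1` differs from compound 2 in one place: 4-oxopiperidin-1-yl in place of piperazin-1-yl on a saturated ring carbon. Going by the values given here, the only measured step touching this part of the molecule is a 2.5-fold lower number from compound 2 to compound 3 (0.40 log units; beyond the scatter), where the same amine nitrogen bore a carbamoyl instead. Among the compounds with values here, no measured pair exchanges the whole ring, so that step bears on the change only indirectly. A modest lowering is therefore expected in this assay, roughly a 1.6-fold lower number from compound 2 to compound 4 (0.20 log units; within the scatter). Compound 4 is estimated at 8 nM, within 3 nM to 25 nM.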

Compound 4, dissociation constant: 1.26 nM
Beside the measured number, compound 4's estimate is 6.3-fold (0.80 log units) above it, outside the stated range (below it).
By their numbers in this assay, from the lowest: compounds 4 and 1 (each within the scatter of the next); then compound 3; then compound 2.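

In this assay, 4-oxopiperidin-1-yl in place of piperazin-1-yl on the saturated ring carbon gives a far larger step (a 10-fold lower number from compound 2 to compound 4 (1.00 log units; beyond the scatter)) than the carbamoyl change did (a 2.5-fold lower number from compound 2 to compound 3 (0.40 log units; beyond the scatter)). The same group also improves on 4-carbamoylpiperazin-1-yl (a 4.0-fold lower number from compound 3 to compound 4 (0.60 log units; beyond the scatter)), so in these pairs a low number does not require the amine nitrogen or a hydrogen-bond donor on this ring. No evidence is available to explain the size of these steps.

The compounds shown leave open whether the carbonyl itself contributes to the lower number. A piperidin-1-yl or 4-hydroxypiperidin-1-yl at the same carbon would separate its contribution from that of removing the amine nitrogen.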